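A few compounds are considered here, and "the series" means these few. Any claim that something is new, unique, unknown or untested is made for them only; others in the source may bear on it.

Measured compounds in the series:

- compound 1 `CCCCCCCCc1ccc(OCC(=O)Cn2nnc(-c3ccccc3Cl)n2)cc1`: 32 nM
- compound 2 `CCCCCCCCc1ccc(OCC(=O)Cn2nnc(-c3ccc(C(=O)OC)cc3)n2)cc1`: 29 nM
- compound 3 `CCCCCCCCc1ccc(OCC(=O)Cn2nnc(-c3cccc(C(=O)OC)c3)n2)cc1`: 34 nM

All three were run in an assay on microsomes from brain for inhibition of Fatty-acid amide hydrolase 1 (Rattus norvegicus), read by fluorescence and HPLC, with a stated time of 60 min; a lower number here means a stronger inhibitor, a higher number a weaker inhibitor. Compound 2 holds the lowest of the three numbers, but its separation from the others is slight: the step of a 1.1-fold lower number from compound 1 to compound 2 (0.04 log units; within the scatter) and the step of a 1.2-fold higher number from compound 2 to compound 3 (0.07 log units; within the scatter) both sit within the scatter, as does the step of a 1.1-fold higher number from compound 1 to compound 3 (0.03 log units; within the scatter). Across these three compounds the group on the shared core has been exchanged without any shift that can be told apart from repeat measurement noise.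

Compound 4 `CCCCCCCCc1ccc(OCC(=O)Cn2nnc(-c3ccncc3)n2)cc1` has not yet been measured in this assay. It differs from compound 2 in one place: pyridin-4-yl in place of 4-(methoxycarbonyl)phenyl on an aromatic carbon. For the measured compounds named here, the steps that bear on this change are the two exchanges of the same group already seen, from compound 1 to compound 2 and from compound 2 to compound 3, each flat within the scatter. Going by the values given here, by the same token no step beyond the scatter is expected for compound 4 in this assay, although the group entering here is the first one with a ring nitrogen in this position, so the expectation is held more loosely than for the measured pairs. The estimated step is a 1.4-fold higher number from compound 2 to compound 4 (0.14 log units; within the scatter). Compound 4 is therefore expected to give about 40 nM in this assay, within a range of 15 nM to 110 nM.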

Compound 4, half-maximal inhibitory concentration: 24 nM
The estimate for compound 4 lay 1.7-fold (0.22 log units) above the measured number, and the stated range covers the measured number.
By their numbers in this assay, from the lowest: compounds 4, 2, 1 and 3 (each within the scatter of the next).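

For the compounds shown here, at this position, on an aromatic carbon of a five-membered aromatic ring with 4 nitrogen, pyridin-4-yl is the only entering group with a hetero atom in its six-membered ring, and it has fewer heavy atoms than 4-(methoxycarbonyl)phenyl. Even so, this assay shows no step beyond the scatter (a 1.2-fold lower number from compound 2 to compound 4 (0.08 log units; within the scatter)) (a 1.4-fold lower number from compound 3 to compound 4 (0.15 log units; within the scatter)) (a 1.3-fold lower number from compound 1 to compound 4 (0.12 log units; within the scatter)), so the flat picture now extends from rings of carbon only to a ring with nitrogen, and the methoxycarbonyl group is not required to hold the number at this level among these four compounds. Nothing on hand accounts for this flatness.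

Still open, as far as these compounds go, is whether the series stays flat with pyridin-2-yl, a carboxylic acid or an amine at this position. The four compounds also leave open how far the number depends on the octyl chain, which a shorter chain would test.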